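Acetyl in Place of Carboxymethyl at the Chain Carbon

The compounds below may be only part of what the source reports. "The series", "measured", "known", "first", "only" and "open" are said of these compounds alone.

Among the measured compounds shown here, compound 2 `CCCn1c(=O)n(CCC(=O)O)c(=O)c2[nH]cnc21` stands at the edge of what an assay on Cerebral cortex for binding affinity to adenosine receptor A1 (Cavia porcellus), read by radioligand binding (a lower number here means a stronger inhibitor, a higher number a weaker inhibitor), can report: its value, > 200000 nM, is a limit rather than a number, and it is the one value among three that sits at this limit (the limit of > 200000 nM in this assay, at which 1 of the 3 values shown sits). Compound 1 `C=CCCn1c(=O)c2[nH]cnc2n(CCC)c1=O` gives 60 nM in this assay, and compound 3 `CCCn1c(=O)n(CCN(C)C)c(=O)c2[nH]cnc21` gives 4300 nM. Compound 4 `CCCn1c(=O)n(CC(C)=O)c(=O)c2[nH]cnc21` differs from compound 2 by acetyl in place of carboxymethyl on a saturated chain carbon bound to an aromatic nitrogen. For the measured compounds named here, two measured steps bear on this change, and both are large: an at least 3300-fold higher number from compound 1 to compound 2 (3.52 log units; beyond the scatter) and an at least 46-fold lower number from compound 2 to compound 3 (1.66 log units; beyond the scatter). Because compound 2 sits at the limit (the limit of > 200000 nM in this assay, at which 1 of the 3 values shown sits), the carboxy appears to carry the loss, so the expected step is an at least 66-fold lower number from compound 2 to compound 4 (1.82 log units; beyond the scatter). Compound 4 is estimated at 3000 nM, in a range from 500 nM to 30000 nM.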

Compound 4, inhibition constant: 11400 nM
Compound 4: the middle estimate sits 3.8-fold (0.58 log units) below what was measured; the measured number falls inside the stated range.
By their numbers in this assay, from the lowest: compound 1; then compound 3; then compound 4. At a limit, above all of these: compound 2.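

Acetyl in place of carboxymethyl gives a measurable value where compound 2 had none, with an at least 17-fold lower number from compound 2 to compound 4 (1.24 log units; beyond the scatter), though that step is only a bound: the limit of > 200000 nM in this assay, at which 1 of the 4 values shown sits.

Removing the carboxy does not restore the binding of compound 1, as a 190-fold higher number from compound 1 to compound 4 (2.28 log units; beyond the scatter) shows, so the loss at this chain carbon is not confined to the carboxy. The acetyl also ends close to the dimethylamino group, with only a 2.7-fold higher number from compound 3 to compound 4 (0.42 log units; beyond the scatter).

The compounds shown leave open whether a hydroxyl or a methyl ester on this chain would stand nearer to compound 1 or to compound 4.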